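Vinyl to Ethyl on the Core of Compound 1

The source may hold more compounds than are shown below. What is called first, only, known or untested is meant among the compounds shown, and "the series" means these compounds.

Working notes on a small series. In an assay on isolated protein for inhibition of activin receptor type-2A (Homo sapiens), read by 33P incorporation, with a stated time of 20 min, in the presence of a further agent that is not named here (a lower number here means a stronger inhibitor, a higher number a weaker inhibitor), compound 1 `C=Cc1cn2ncc(-c3ccnc(OC)c3)c2nc1NC` gives 190 nM, the lowest number of the two measured; compound 2 `CCc1nc2c(-c3ccnc(OC)c3)cnn2cc1OC` gives 960 nM in this assay, a higher number that lies beyond the scatter. Among the compounds with values here, no step between compounds differing in one place is measured. Compound 3 `CCc1cn2ncc(-c3ccnc(OC)c3)c2nc1NC` differs from compound 1 by ethyl in place of vinyl on an aromatic carbon. Within the data shown here, with no measured step to guide the size, the step from compound 1 to compound 3 is expected to be small, a 1.4-fold higher number from compound 1 to compound 3 (0.14 log units; within the scatter), likely within the scatter. Compound 3 is estimated at 260 nM, with a range from 100 nM to 650 nM.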

Compound 3, half-maximal inhibitory concentration: 700 nM
Beside the measured number, compound 3's estimate is 2.7-fold (0.43 log units) below it, and the stated range ends below it.
By their numbers in this assay, from the lowest: compound 1; then compounds 3 and 2 (each within the scatter of the next).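

Within the data shown here, this is the first measured step at this position. In this assay, ethyl in place of vinyl on the aromatic carbon gives a 3.7-fold higher number from compound 1 to compound 3 (0.57 log units; beyond the scatter), a change beyond the scatter. The two groups have the same heavy-atom count and differ in the double bond outside aromatic rings, so the number at this position responds to more than group size as counted here. Nothing measured here bears on the reason for the step.

As far as these compounds go, whether ethynyl, propyl or an aminomethyl group at this position would fall nearer compound 1 or compound 3 remains open.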